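A fluorine for two chlorines on the sulfur-linked benzyl

The source may report more compounds than this note shows. Statements on the series, on what has been measured and on what is new or still open speak of the compounds shown alone.

Compound 1, `COc1ccccc1/C=C(/SCc1ccc(Cl)c(Cl)c1)C(=O)c1ccc(Cl)cc1`: 10000 nM in a functional assay on DU-145 cells (Homo sapiens) for inhibition, read by trypan blue exclusion, with a stated time of 96 h; on this read-out lower numbers stand for stronger inhibition of growth and higher numbers for weaker inhibition of growth
Compound 2, `O=C(/C(=C\c1ccccc1OCc1ccccc1)SCc1ccc(Cl)c(Cl)c1)c1ccc(Cl)cc1`: 10000 nM in this assay

Compound 1 and compound 2 share one core and differ in a single place. The step from one to the other, no change at the digits printed from compound 1 to compound 2 (within the scatter), moved nothing, so compound 1 stands level with compound 2 on the growth-inhibition read-out, and both sit at the weak end of what was measured.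

Compound 3, `COc1ccccc1/C=C(/SCc1ccccc1F)C(=O)c1ccc(Cl)cc1`, is the next variation. It differs from compound 1 in this way: 2-fluorophenyl in place of 3,4-dichlorophenyl on a saturated chain carbon bound to a sulfur. Among the compounds with values here, this change sits on the sulfur side of the core, whereas the only measured step touched the oxygen side of the core. That step therefore bears on compound 3 only indirectly: it shows that one part of the core tolerated a large change without any shift in this assay, but it says nothing directly about the benzyl group bound to sulfur.

Within the data shown here, with no step at this place to draw on, the expectation is no change beyond the scatter, no change at the digits printed from compound 1 to compound 3 (within the scatter). Compound 3 is therefore estimated at 10000 nM in this assay, with a range from 4000 nM to 25000 nM.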

Compound 3, concentration for 50% growth inhibition: 10000 nM
Compound 3: the middle estimate sits on the measured number at the digits printed; measured number inside the range.
By their numbers in this assay, from the lowest: compounds 1, 2 and 3 (each within the scatter of the next).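

The sulfur side of the core now has a measured step of its own: the swap from 3,4-dichlorobenzyl to 2-fluorobenzyl gives no change at the digits printed from compound 1 to compound 3 (within the scatter) in this assay. Taken with the change on the oxygen side, which gives no change at the digits printed from compound 1 to compound 2 (within the scatter), this means that neither of the two changes made to compound 1 moved the growth-inhibition number, and all three compounds remain at the weak end of what is shown here. No information on the properties of these groups is available to account for this flat result.

This one step removes both chlorines and brings in a fluorine on a different part of the ring, and the data cannot separate those two parts of the swap, nor show how a plain phenyl with no halogen would read at this place. As far as these compounds go, it also remains open whether a more different group on the saturated chain carbon bound to the sulfur, such as a ring bearing an amine or a carboxylic acid, or a longer chain between the sulfur and the ring, would shift the number at all.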